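Benzyl in place of phenyl on the indoline nitrogen

The compounds below may be only part of what the source reports. "The series", "measured", "known", "first", "only" and "open" are said of these compounds alone.

Measured so far in a functional assay on SK-HEP1 cells (Homo sapiens) for inhibition, read by sulforhodamine B assay, with a stated time of 48 h; on this read-out lower numbers stand for stronger inhibition and higher numbers for weaker inhibition:
compound 1, `O=C(Nc1ccc2c(c1)CCN2c1ccc(C(=O)NO)cc1)Nc1ccc(Cl)c(C(F)(F)F)c1`: 4100 nM
compound 2, `O=C(Nc1ccc2c(c1)CCCN2c1ccc(C(=O)NO)cc1)Nc1ccc(Cl)c(C(F)(F)F)c1`: 3400 nM
compound 3, `O=C(CCCCCC(=O)Nc1ccc(NC(=O)Nc2ccc(Cl)c(C(F)(F)F)c2)cc1)NO`: > 10000 nM

Compound 1 gives the highest of the two numbers in this assay, and compound 2 sits within the scatter of it, so no order between them can be read. For compound 3 the value is a limit of this assay and not a number (the limit of > 10000 nM in this assay, at which 1 of the 3 values shown sits).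

Compound 4, `O=C(Nc1ccc2c(c1)CCN2Cc1ccc(C(=O)NO)cc1)Nc1ccc(Cl)c(C(F)(F)F)c1`, has not yet been measured. It differs from compound 1 in one place: 4-(hydroxycarbamoyl)benzyl in place of 4-(hydroxycarbamoyl)phenyl on a nitrogen on an aromatic ring in a ring. Among the compounds with values here, no step between two measured compounds of this kind exists, so the size of this change in this assay is open. Given that compound 1 gives 4100 nM, a step from compound 1 to compound 4 of no more than the scatter, or a small weakening, is expected. Compound 4 is therefore estimated at 5500 nM, between 1800 nM and 16000 nM, which means an expected step of a 1.3-fold higher number from compound 1 to compound 4 (0.13 log units; within the scatter).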

Compound 4, half-maximal inhibitory concentration: 4600 nM
For compound 4 the middle estimate is 1.2-fold (0.08 log units) above the measured one; measured number inside the range.
By their numbers in this assay, from the lowest: compounds 2, 1 and 4 (each within the scatter of the next). At a limit, above all of these: compound 3.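

In this assay, 4-(hydroxycarbamoyl)benzyl in place of 4-(hydroxycarbamoyl)phenyl on this nitrogen gives a 1.1-fold higher number from compound 1 to compound 4 (0.05 log units; within the scatter). This is the only single-place step shown at this position, and it shows that this one change leaves the number within the scatter. No measurement shown gives a cause for this.

Still open, going by these compounds, is whether a longer chain, such as 4-(hydroxycarbamoyl)phenethyl, would also stay within the scatter of compound 1. Also open, on these data alone, is what a carboxylic acid in place of the hydroxycarbamoyl group would do on this nitrogen.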